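The compounds below may be only part of what the source reports. "The series", "measured", "known", "first", "only" and "open" are said of these compounds alone.

Working notes on the series, read in an ADME assay on microsomes from liver (Homo sapiens) for metabolic stability, with a stated time of 60 min, tested at 1 uM; on this read-out higher numbers stand for a more stable compound and lower numbers for a less stable compound. Compound 1 `COc1cc(-c2cnn3cc(OC)c(-c4cnn(C)c4)nc23)ccn1` gives 43%, compound 2 `COc1cc(-c2cnn3cc(OC)c(-c4cc(C)no4)nc23)ccn1` gives 31%, and compound 3 `COc1cc(-c2cnn3cc(OC)c(N(C)C)nc23)ccn1` gives 16%. Compound 3 is the lowest of the three, and both steps into it lie beyond the scatter: a number 27 percentage points lower from compound 1 to compound 3 (beyond the scatter) and a number 15 percentage points lower from compound 2 to compound 3 (beyond the scatter).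

Compound 4 `COc1cc(-c2cnn3cc(OC)c(C4CCCC4)nc23)ccn1` carries cyclopentyl in place of dimethylamino on the same aromatic carbon: cyclopentyl in place of dimethylamino on an aromatic carbon. Three measured steps change this carbon. Besides the two above, there is a number 12 percentage points lower from compound 1 to compound 2 (beyond the scatter), which stays between two rings and shows that the choice of ring can matter. Read backwards, a number 27 percentage points lower from compound 1 to compound 3 (beyond the scatter) and a number 15 percentage points lower from compound 2 to compound 3 (beyond the scatter) show a higher number in both cases where a ring stands in place of dimethylamino. That favours a rise for compound 4, but both rings in those pairs are aromatic, whereas cyclopentyl is a non-aromatic ring of carbon only. Among the measured compounds shown here, no measured compound carries such a ring, so the rise is expected to be smaller than those modest steps and may stay within the scatter. The expected change is a number 6 percentage points higher from compound 3 to compound 4 (within the scatter). For compound 4 the estimated value is 22%, with an expected range from 8% to 40%.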

Compound 4, percent of the compound remaining: 32%
Compound 4: the middle estimate sits 10 percentage points below what was measured; low and high end bracket the measured number.
By their numbers in this assay, from the lowest: compound 3; then compounds 2 and 4 (each within the scatter of the next); then compound 1.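

In this assay, the rise seen when an aromatic ring replaces dimethylamino also appears with a non-aromatic ring of carbon only: a number 16 percentage points higher from compound 3 to compound 4 (beyond the scatter). At this aromatic carbon, cyclopentyl and 3-methyl-1,2-oxazol-5-yl cannot be told apart, with a number 1 percentage points higher from compound 2 to compound 4 (within the scatter), so in this pair an aromatic ring and a non-aromatic ring give values within the scatter. The 1-methyl-1H-pyrazol-4-yl group keeps its lead over cyclopentyl, with a number 11 percentage points lower from compound 1 to compound 4 (beyond the scatter), which shows that the three rings at this carbon do not all read alike and that compound 1 stands apart from both compound 2 and compound 4.

No data are at hand that explain these differences in stability. Going by these compounds, it stays open whether the gain follows the ring itself or simply the loss of dimethylamino, a question that an open-chain carbon group such as isopropyl or a ring amine such as morpholine at this same carbon would help to separate.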